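This account rests on a few compounds, and the source may have more. Where it says the series, first, only, none or still open, it means among the compounds named here.

Measured compounds:
compound 1 `O=C(N/N=C/c1cccc(Br)c1)Nc1ccc(Oc2ccnc3[nH]ccc23)c(F)c1` — 2220 nM
compound 2 `O=C(N/N=C/c1ccc(O)cc1)Nc1ccc(Oc2ccnc3[nH]ccc23)cc1` — 1910 nM

Two semicarbazones sharing one core were tested in a functional assay on A549 cells (Homo sapiens) for antiproliferative activity, read by MTT assay, with a stated time of 72 h; a higher number here means a weaker inhibitor, a lower number a stronger inhibitor. Compound 1 gives 2220 nM, and compound 2 gives 1910 nM. Of the two numbers, that of compound 1 is the higher, but the two values sit within the scatter of each other, so nothing can be said about an order between compound 1 and compound 2.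

The account then turns to compound 3 `CN(C)CCn1cccc1/C=N/NC(=O)Nc1ccc(Oc2ccnc3[nH]ccc23)c(F)c1`, which is not yet measured. It is derived from compound 1 by one change: 1-(2-(dimethylamino)ethyl)-1H-pyrrol-2-yl in place of 3-bromophenyl on a carbon with a double bond to nitrogen. For the measured compounds named here, no step between measured compounds bears on this change, and compound 2 differs from compound 1 in more than one place, so its value offers no guide to the size of the change. In this assay the step is therefore expected to be small, with no direction that can be stated with confidence, and is estimated to fall within the scatter: a 1.4-fold lower number from compound 1 to compound 3 (0.14 log units; within the scatter). For compound 3 the value is estimated at 1600 nM, with a range from 400 nM to 6500 nM.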

Compound 3, half-maximal inhibitory concentration: "not active" (no number reported)
Compound 3: no number reported, and the estimate cannot be compared.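

In this assay, for the compounds shown here, compound 3 is reported as not active, with no number, so no step from compound 1 to compound 3 can be read. Nothing shown here offers an explanation for this result. The compounds shown leave open how large the effect of 1-(2-(dimethylamino)ethyl)-1H-pyrrol-2-yl in place of 3-bromophenyl is in this assay.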